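Methoxy on the Ring of Compound 2: An Expected Inhibition Constant

The compounds below may be only part of what the source reports. "The series", "measured", "known", "first", "only" and "open" are said of these compounds alone.

Measured compounds:
- compound 1, `C#CCN(C)Cc1cn(Cc2ccccc2)c2ccccc12`: 158000 nM
- compound 2, `C#CCNCc1cc2ccccc2n1C`: 240 nM
- compound 3, `C#CCN(Cc1ccccc1)Cc1cc2ccccc2n1C`: 10000 nM

In an assay on isolated protein for inhibition of Amine oxidase [flavin-containing] A (Rattus norvegicus) (on this read-out lower numbers stand for stronger inhibition and higher numbers for weaker inhibition), compound 2 gives the lowest number of the three, with compound 3 nearest and compound 1 furthest. Compound 4, `C#CCNCc1cc2cc(OC)ccc2n1C`, differs from compound 2 by methoxy in place of hydrogen on an aromatic carbon. Among the measured compounds shown here, the only step measured in one place, a 42-fold higher number from compound 2 to compound 3 (1.62 log units; beyond the scatter), concerns the amine nitrogen, not the aromatic ring, so it does not bear directly on this change. Nothing measured here shows what a methoxy on the ring does. Compound 4 is therefore expected to stay close to compound 2, with a 1.3-fold higher number from compound 2 to compound 4 (0.10 log units; within the scatter) likely within the scatter. The estimate for compound 4 is 300 nM, between 60 nM and 1500 nM.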

Compound 4, inhibition constant: 0.813 nM
Compound 4: the middle estimate sits 370-fold (2.57 log units) above what was measured, outside the stated range (below it).
By their numbers in this assay, from the lowest: compound 4; then compound 2; then compound 3; then compound 1.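

In this assay, methoxy in place of hydrogen on this aromatic carbon, meta to a fused ring and para to a fused ring, gives a 300-fold lower number from compound 2 to compound 4 (2.47 log units; beyond the scatter). Among the compounds shown here, the ring carbon is thus a place where one change lowers the number strongly, whereas the only earlier step, at an amine nitrogen, raised it. Nothing available here accounts for the size of this step.

Going by these compounds, whether a hydroxyl, a methyl or a chlorine on the same carbon would do the same remains open. So does whether methoxy would act alike with the benzyl of compound 3 on the amine nitrogen.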